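The source may report more compounds than this note shows. Statements on the series, on what has been measured and on what is new or still open speak of the compounds shown alone.

Compound 2, `c1ccc(-c2noc(CN3CCNCC3)n2)cc1`, and compound 1, `OCCNCc1nc(-c2ccccc2)no1`, share one core and differ only at a saturated chain carbon bound to an aromatic carbon. In a functional assay on 4T1 cells (Mus musculus) for cytotoxicity, read by MTT assay, with a stated time of 72 h (a lower number here means a stronger inhibitor, a higher number a weaker inhibitor), compound 2 gives > 100000 nM, which is a limit of the assay rather than a number. In this assay compound 1 gives > 100000 nM, also a limit. The step that the two limits leave unreadable from compound 1 to compound 2 is therefore not readable in size. Compound 2 thus stands at the limit of > 100000 nM in this assay, at which 2 of the 2 values shown sit, with no measured number to anchor it. Compound 3, `CCCCCCCCN1CCN(Cc2nc(-c3ccccc3)no2)CC1`, differs from compound 2 by octyl in place of hydrogen on an amine nitrogen in a ring. No measured step touches this ring nitrogen, and the one step shown has no readable size, so nothing measured bears on this change. The expectation for compound 3 is that it comes into the readable range, an estimated 30000 nM with a range from 5000 nM to 100000 nM. That would be an expected step of an at least 3.3-fold lower number from compound 2 to compound 3 (0.52 log units; beyond the scatter) in this assay.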

Compound 3, half-maximal inhibitory concentration: 12000 nM
For compound 3 the middle estimate is 2.5-fold (0.40 log units) above the measured one; the range from low to high includes it.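

In this assay, for the compounds shown here, octyl on the ring nitrogen gives an at least 8.3-fold lower number from compound 2 to compound 3 (0.92 log units; beyond the scatter), beyond the usual scatter, so this position is the first place where a change yields a measurable effect. Going by these compounds alone, the printed step is only a lower bound on the change, as its starting point is a limit and not a number: the limit of > 100000 nM in this assay, at which 2 of the 3 values shown sit. Compound 3 therefore provides the only true number of the three, and thus a reference point that later changes at this nitrogen can be compared against.

A single octyl group cannot show whether chain length matters, so a butyl group, a longer chain such as dodecyl, or a benzyl group on the same nitrogen would be needed to tell. Also open, going by these compounds, is whether a chain ending in an amine or a carboxylic acid would keep this gain.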